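Benzyl ether series: cytotoxicity step to compound 4

A few compounds are considered here, and "the series" means these few. Any claim that something is new, unique, unknown or untested is made for them only; others in the source may bear on it.

The compounds share one core and differ only in the benzyl ether. Compound 1 `O=c1c(OCc2ccccc2Cl)c(-c2ccccc2)oc2cc(O)cc(O)c12` is read in an ADME assay on Huh-5-2 cells (Homo sapiens) for cytotoxicity, read by WST assay, with a stated time of 3 days (a higher number here means that more compound is tolerated, a lower number that less compound is tolerated), as > 100000 nM, which is a limit of the assay and not a number (the limit of > 100000 nM in this assay, at which 1 of the 3 values shown sits). Compound 2 `Cc1ccccc1COc1c(-c2ccccc2)oc2cc(O)cc(O)c2c1=O` gives 55000 nM in this assay, and compound 3 `COc1ccccc1COc1c(-c2ccccc2)oc2cc(O)cc(O)c2c1=O` gives 53000 nM. On the numbers shown, compound 3 sits alongside compound 2 within the scatter, with compound 1 given only as a limit. The measured steps read an at least 1.8-fold lower number from compound 1 to compound 2 (0.25 log units; that floor lies within the scatter), an at least 1.8-fold lower number from compound 1 to compound 3 (0.27 log units; that floor lies within the scatter) and a 1.0-fold lower number from compound 2 to compound 3 (0.02 log units; within the scatter). Compound 4 `O=c1c(OCc2cccc(Br)c2)c(-c2ccccc2)oc2cc(O)cc(O)c12` has not been measured; it differs from compound 3 by 3-bromophenyl in place of 2-methoxyphenyl on a saturated chain carbon bound to an oxygen on an aromatic ring. The two steps leaving compound 1 bear on this change in reverse, since a halogen comes back in place of methoxy, but both floors lie within the scatter, and the step between compound 2 and compound 3 shows no movement. A small rise or no step beyond the scatter is therefore expected in this assay, estimated as a 1.4-fold higher number from compound 3 to compound 4 (0.15 log units; within the scatter). Compound 4 is estimated at 75000 nM, with a range from 35000 nM to 160000 nM.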

Compound 4, half-maximal cytotoxic concentration: 15000 nM
For compound 4 the middle estimate is 5.0-fold (0.70 log units) above the measured one; the measured number lies below the stated range.
By their numbers in this assay, from the lowest: compound 4; then compounds 3 and 2 (each within the scatter of the next). At a limit, above all of these: compound 1.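

In this assay, among the compounds shown here, 3-bromophenyl in place of 2-methoxyphenyl gives the first step that lies clearly beyond the scatter: a 3.5-fold lower number from compound 3 to compound 4 (0.55 log units; beyond the scatter), and the step from the 2-methylphenyl compound matches it, a 3.7-fold lower number from compound 2 to compound 4 (0.56 log units; beyond the scatter). Against the 2-chlorophenyl of compound 1 the step is an at least 6.6-fold lower number from compound 1 to compound 4 (0.82 log units; beyond the scatter), but compound 1 is given only as a limit of the assay, not a number: the limit of > 100000 nM in this assay, at which 1 of the 4 values shown sits. A halogen on this ring therefore does not by itself go with a high tolerated concentration, since compound 1 and compound 4 both carry one and stand at opposite ends of the values shown.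

Compound 4 differs from compound 1 in both the halogen and its place on the ring, and the compounds shown cannot separate the two; 2-bromophenyl or 3-chlorophenyl would do so. Going by these compounds, how an amine or a carboxylic acid on this ring would read remains open.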